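The source may hold more compounds than are shown below. What is called first, only, known or untested is meant among the compounds shown, and "the series" means these compounds.

Measured compounds:
- compound 1, `COC(=O)c1nc(-c2ccco2)c(C(F)(F)F)cc1N`: 5310 nM
- compound 2, `CNC(=O)c1nc(Br)c(C(F)(F)F)cc1N`: 250 nM

In an assay on CHO cells for positive allosteric modulation of Cystic fibrosis transmembrane conductance regulator variant F508del (Homo sapiens), using a membrane potential dye, with a stated time of 30 min, in the presence of a further agent that is not named here (a higher number here means that more compound is needed for the effect, a lower number that less compound is needed), compound 2 gives 250 nM, the lowest of the two numbers available. Within the data shown here, the nearest comparison is compound 1, which in this assay gives 5310 nM, a gap beyond the usual scatter; since these two compounds differ in more than one place, no single step between them can be read from the data. Compound 3, `Nc1cc(C(F)(F)F)c(Br)nc1C(=O)NCCC(F)(F)F`, differs from compound 2 only by 2,2,2-trifluoroethyl in place of hydrogen on a saturated chain carbon bound to an amide-type nitrogen. Among the measured compounds shown here, no measured step of this kind exists in this set, so the direction of the change is unknown. The step from compound 2 to compound 3 is expected to be small, about a 1.2-fold higher number from compound 2 to compound 3 (0.08 log units; within the scatter), in either direction or none beyond the scatter. For compound 3 in this assay the estimate is 300 nM, with a range from 100 nM to 1000 nM.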

Compound 3, half-maximal effective concentration: 40 nM
Compound 3: middle estimate off by 7.5-fold (0.88 log units), on the high side; the measured number lies below the stated range.
By their numbers in this assay, from the lowest: compound 3; then compound 2; then compound 1.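

In this assay, the saturated chain carbon bound to an amide-type nitrogen proves to be a place where a change registers: 2,2,2-trifluoroethyl in place of hydrogen there gives a 6.3-fold lower number from compound 2 to compound 3 (0.80 log units; beyond the scatter). Among these compounds, this is the first step in the set that can be read in one place, and it shows that the methylamino group of compound 2 can be extended to (3,3,3-trifluoropropyl)amino with a lower number rather than a loss. No data offered here give a reason for this drop.

The compounds shown leave open whether the step belongs to the fluorine atoms or to the length of the chain, which a plain propyl group on the amide-type nitrogen would separate. They also leave open how the number responds to a longer chain, such as 4,4,4-trifluorobutyl, or to a cyclopropyl group there.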